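Adding Chlorine to a Benzyl Arm: Cytotoxicity Expectation

A few compounds are considered here, and "the series" means these few. Any claim that something is new, unique, unknown or untested is made for them only; others in the source may bear on it.

Compound 1 `COc1ccc(S(=O)(=O)Nc2nnc(SCc3ccccc3)s2)cc1` and compound 2 `COc1ccc(S(=O)(=O)Nc2nnc(SCc3ccc(Cl)cc3)s2)cc1` share one core, while compound 3 `Cc1cc(C)c(S(=O)(=O)Nc2nnc(SCc3ccccc3)s2)c(C)c1` and compound 4 `Cc1cc(C)c(S(=O)(=O)Nc2nnc(SCc3ccc(Cl)cc3)s2)c(C)c1` share another; the difference between the two cores is not broken down here. In a toxicity assay on HaCaT cells (Homo sapiens) for cytotoxicity, tested at 125 uM (a lower number here means a stronger effect, a higher number a weaker effect of the compound at the concentration tested), compound 1 gives 79%, compound 2 gives 90% and compound 3 gives 73%. The change from compound 1 to compound 2 is chloro in place of hydrogen on an aromatic carbon, and it made a number 11 percentage points higher from compound 1 to compound 2 (beyond the scatter). The same change, (chloro in place of hydrogen on an aromatic carbon), leads from compound 3 to compound 4. Going by the values given here, because a number 11 percentage points higher from compound 1 to compound 2 (beyond the scatter) is the only measured example of this change, the expectation for compound 4 rests on it alone, carried over to the core of compound 3. On that basis a step of about a number 11 percentage points higher from compound 3 to compound 4 (beyond the scatter) is expected. Compound 4 is therefore estimated at 84%, within 72% to 95%.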

Compound 4, a percentage reported as activity, at one concentration (the size of the read-out at that concentration, not a potency): 87%
Compound 4: the middle estimate sits 3 percentage points below what was measured, within the range that was stated.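

Putting chloro in place of hydrogen on the benzyl arm of the second core also raises the number in this assay (a number 14 percentage points higher from compound 3 to compound 4 (beyond the scatter)), so the change carries over between these two cores at a similar size: the same change on two cores in this assay, a number 11 percentage points higher (beyond the scatter) from compound 1 to compound 2 and a number 14 percentage points higher (beyond the scatter) from compound 3 to compound 4, 3 percentage points apart, within the scatter of two such steps. The two chlorinated compounds show no separation beyond the scatter (a number 3 percentage points lower from compound 2 to compound 4 (within the scatter)), so swapping 4-methoxyphenyl for 2,4,6-trimethylphenyl changes little in this chlorinated pair. Two cores and a single substituent cannot show that the step would hold on other cores, and they do not explain why the number rises.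

From the compounds shown here alone, whether fluoro, methoxy or an amine in the same place would shift the number in the same way remains open. So does the size of the step on a core carrying a different group on the sulfonyl sulfur, such as a simple phenyl.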